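Cytotoxicity series: a chloro step from an inactive parent

The source may report more compounds than this note shows. Statements on the series, on what has been measured and on what is new or still open speak of the compounds shown alone.

Measured compounds:
Compound 1 `COc1ccc2[nH]c(=O)c(-c3nc4cc(Cl)ccc4[nH]3)cc2c1`: > 100000 nM (a limit of the assay)
Compound 2 `Cc1ccc2[nH]c(=O)c(-c3nc4ccccc4[nH]3)cc2c1`: > 100000 nM (a limit of the assay)

In a functional assay on NCI-H460 cells (Homo sapiens) for cytotoxicity, read by MTT assay, with a stated time of 48 h (on this read-out higher numbers stand for weaker inhibition and lower numbers for stronger inhibition), compound 1 gives > 100000 nM, which is a limit of the assay and not a number. In this assay compound 2 likewise gives > 100000 nM, again a limit and not a number. Compound 2 therefore stands at the top of what this assay can report, and every value shown in the series sits there too (the limit of > 100000 nM in this assay, at which 2 of the 2 values shown sit). Going by the values given here, no step between measured compounds that differ in one place is available, so no measured effect of any single change is known.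

Compound 3 `Cc1ccc2[nH]c(=O)c(-c3nc4cc(Cl)ccc4[nH]3)cc2c1` differs from compound 2 by chloro in place of hydrogen on an aromatic carbon. With both measured values at the limit, the expected step is a number no higher from compound 2 to compound 3 (the limit leaves the size open), nothing beyond the scatter. Compound 3 is expected at 100000 nM, with a range from 30000 nM to 300000 nM, and most likely reported as a limit again.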

Compound 3, half-maximal inhibitory concentration: 36500 nM
Compound 3: middle estimate off by 2.7-fold (0.44 log units), on the high side; measured number inside the range.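

In this assay, chloro in place of hydrogen on an aromatic carbon gives an at least 2.7-fold lower number from compound 2 to compound 3 (0.43 log units; beyond the scatter), so this position can move the read-out off the limit when methyl is present on the core. Compound 1 carries the same chloro and gives > 100000 nM, which is a limit of the assay, so chloro alone does not bring a measurable value in the compounds shown. Methyl in place of methoxy on an aromatic carbon gives an at least 2.7-fold lower number from compound 1 to compound 3 (0.43 log units; beyond the scatter), and the full size of both steps stays open because each starts from a limit: the limit of > 100000 nM in this assay, at which 2 of the 3 values shown sit.

On these data alone, whether bromo, fluoro or an amine at the chloro position would give a lower number than compound 3 remains open. So does whether an ethyl group or a longer chain in place of the methyl keeps the number measurable.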